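The compounds below may be only part of what the source reports. "The series", "measured", "known", "first", "only" and "open" are said of these compounds alone.

For the measured compounds named here, compound 1 (`COc1ccc(Br)cc1Cn1c(C(=O)NCC(C)(C)CO)cc2cc(C#N)ccc21`) gives 23 mL.min-1.g-1 in an in vitro ADME assay on microsomes from liver (Homo sapiens) for metabolic stability, in the presence of a further agent that is not named here (a lower number here means slower removal, a higher number faster removal of the compound), and compound 2 (`Cc1ccc(Cl)cc1Cn1c(C(=O)NCC(C)(C)CO)cc2cc(C#N)ccc21`) gives 23 mL.min-1.g-1 there, so compound 2 stands level with compound 1, its only measured neighbour. Compound 3 (`Cc1ccc(C)c(Cn2c(C(=O)NCC(C)(C)CO)cc3cc(C#N)ccc32)c1`) differs from compound 2 by one exchange (methyl in place of chloro on an aromatic carbon), methyl in place of chloro on an aromatic carbon. Going by the values given here, the sole measured step (no change at the digits printed from compound 1 to compound 2 (within the scatter)) put 5-chloro-2-methylphenyl in place of 5-bromo-2-methoxyphenyl and stayed within the scatter, so no step beyond the scatter is expected in this assay here, though one step is thin evidence. The expected step (a 1.0-fold higher number from compound 2 to compound 3 (0.02 log units; within the scatter)) has no firm direction. Compound 3 is estimated at 24 mL.min-1.g-1 within a range of 14 mL.min-1.g-1 to 40 mL.min-1.g-1 overall.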

Compound 3, intrinsic clearance in microsomes: 29 mL.min-1.g-1
Beside the measured number, compound 3's estimate is 1.2-fold (0.08 log units) below it, within the range that was stated.
By their numbers in this assay, from the lowest: compounds 1, 2 and 3 (each within the scatter of the next).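

Exchanging chloro for methyl on the aromatic carbon para to a methyl group gives a 1.3-fold higher number from compound 2 to compound 3 (0.10 log units; within the scatter) in this assay, so at this position a halogen and a carbon substituent stay within the scatter of each other. The wider exchange to 2,5-dimethylphenyl gives a 1.3-fold higher number from compound 1 to compound 3 (0.10 log units; within the scatter), so all three aryl groups shown remain level in this read-out. As far as these compounds go, whether an amine, a carboxylic acid or a longer chain at this position would produce a step beyond the scatter remains open. No evidence shown bears on why these numbers stay so close.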